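The source may hold more compounds than are shown below. What is called first, only, known or untested is meant among the compounds shown, and "the series" means these compounds.

The measured compounds:
compound 1, `Nc1cc(N)c2nc(-c3ccccc3)c(Sc3ccc(F)cc3)nc2c1`, gives 20400 nM
compound 2, `COc1cc(CNc2nc3cc(N)cc(N)c3nc2-c2ccccc2)cc(OC)c1OC`, gives 3020 nM
compound 3, `CCOC(=O)[C@H](CCC(=O)O)NC(=O)c1ccc(Oc2nc3cc(N)cc(N)c3nc2-c2ccccc2)cc1`, gives 67600 nM

All three values come from a functional assay on NCI-H322M cells (Homo sapiens) for inhibition, read by sulforhodamine B assay, with a stated time of 48 h; a lower number here means a stronger inhibitor of growth, a higher number a weaker inhibitor of growth. Among these numbers compound 1 holds the second highest, with compound 3 the nearest and compound 2 the furthest away. Compound 4, `COc1ccc(Sc2nc3cc(N)cc(N)c3nc2-c2ccccc2)cc1`, has not yet been measured; it keeps the core of compound 1 and alters a single group: methoxy in place of fluoro on an aromatic carbon. Going by the values given here, no pair of measured compounds shows what this change by itself does in this assay, so the size of the step must be guessed rather than read from a neighbour. A shift within the scatter, or at most a modest move toward a lower number, seems the likeliest outcome. The expected step from compound 1 to compound 4 is a 1.4-fold lower number from compound 1 to compound 4 (0.13 log units; within the scatter). Compound 4 is estimated to give 15000 nM in this assay, within a range of 4000 nM to 60000 nM.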

Compound 4, concentration for 50% growth inhibition: 35500 nM
Compound 4: middle estimate off by 2.4-fold (0.37 log units), on the low side; the range from low to high includes it.
By their numbers in this assay, from the lowest: compound 2; then compounds 1, 4 and 3 (each within the scatter of the next, the first and the last beyond it).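

Going by these compounds alone, changing (4-fluorophenyl)sulfanyl to (4-methoxyphenyl)sulfanyl on the shared core gives the first direct comparison at this position in this assay (a 1.7-fold higher number from compound 1 to compound 4 (0.24 log units; within the scatter)). The step lies within the scatter, so this single swap shows no real change in growth inhibition. Nothing available explains this result.

On these data alone, it remains open whether an amine or a carboxylic acid in place of fluoro or methoxy would shift the value beyond the scatter. The compounds shown also leave open whether the same swap behaves alike on a different linker to the core.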